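Naphthalen-1-yl for 2-methoxyphenyl in compound 1

This account rests on a few compounds, and the source may have more. Where it says the series, first, only, none or still open, it means among the compounds named here.

Among the measured compounds shown here, compound 1 `COc1ccccc1/C=C/C(=O)/C=C/c1ccc(OCc2cn(CCOc3cc(=O)oc4ccccc34)nn2)c(OC)c1` gives 75% in a functional assay on THP-1 cells (Homo sapiens) for inhibition, read by sulforhodamine B assay, with a stated time of 48 h, tested at 50 uM (a lower number here means less inhibition of growth, a higher number more inhibition of growth at the concentration tested), the higher of the two numbers measured so far. Compound 2 `COc1cc(/C=C/C(=O)/C=C/c2cccs2)ccc1OCc1cn(CCCCCOc2cc(=O)oc3ccccc23)nn1` gives 34% in this assay, a number lying beyond the scatter below that of compound 1. Compound 3 `COc1cc(/C=C/C(=O)/C=C/c2cccc3ccccc23)ccc1OCc1cn(CCOc2cc(=O)oc3ccccc23)nn1` differs from compound 1 by naphthalen-1-yl in place of 2-methoxyphenyl on a double-bonded chain carbon bound to a double-bonded chain carbon. For the measured compounds named here, no two measured compounds differ in a single place, so the size of this step has no measured precedent here. A moderate fall is expected, amounting to a number 13 percentage points lower from compound 1 to compound 3 (beyond the scatter). Compound 3 is thus estimated at 62% in this assay, with a range from 38% to 85%.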

Compound 3, percent growth inhibition at one concentration: 89%
Compound 3: the middle estimate sits 27 percentage points below what was measured; the measured number lies above the stated range.
By their numbers in this assay, from the lowest: compound 2; then compound 1; then compound 3.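

In this assay, naphthalen-1-yl in place of 2-methoxyphenyl gives a number 14 percentage points higher from compound 1 to compound 3 (beyond the scatter). This place on the double-bonded chain carbon therefore does not need the methoxy group or its hydrogen-bond acceptor to retain growth inhibition, and it accepts two six-membered aromatic rings of carbon only. No available data bear on the cause of this rise. As far as these compounds go, it remains open whether a plain phenyl or a naphthalen-2-yl group here would match compound 3. Also unresolved is how a dimethylamino group on the naphthalen-1-yl ring would affect growth inhibition.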